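The source may hold more compounds than are shown below. What is called first, only, known or untested is meant among the compounds shown, and "the series" means these compounds.

Measured compounds:

- Compound 1 `CCOc1nn2cc(-c3cc4ccccc4o3)nc2s1` — 67 nM
- Compound 2 `COc1cc(OCc2cccc(CCc3ccccc3)c2)c2cc(-c3cn4nc(OC)sc4n3)oc2c1` — 2.4 nM
- Compound 3 `CCSc1nn2cc(-c3cc4ccccc4o3)nc2s1` — 2900 nM

In a functional assay on HEK293 cells for antagonist activity at proteinase-activated receptor 4 (Homo sapiens), read by FLIPR and calcium flux, with a stated time of 30 min (a higher number here means a weaker inhibitor, a lower number a stronger inhibitor), compound 2 gives the lowest of the three numbers; compound 1 sits a good way above it and compound 3 further still, both gaps beyond the scatter. Compound 4 `COc1cc(OCc2cccc(Sc3ccccc3)c2)c2cc(-c3cn4nc(OC)sc4n3)oc2c1` has not yet been measured. It differs from compound 2 in one place: phenylsulfanyl in place of phenethyl on an aromatic carbon. The linker carrying the outer ring is thus exchanged, while the shared core and the methoxy-bearing portion of compound 2 are kept.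

Among the measured compounds shown here, the only step measured within one place, a 43-fold higher number from compound 1 to compound 3 (1.64 log units; beyond the scatter), concerns a different part of the molecule and a different exchange, ethylsulfanyl for ethoxy on the core, so it bears on the present step only loosely; it does show that sulfur for oxygen at that site cost a great deal. For the measured compounds named here, no step with phenylsulfanyl for phenethyl has been measured. The expectation is therefore a small step in this assay, of either direction, around a 1.7-fold higher number from compound 2 to compound 4 (0.22 log units; within the scatter). Compound 4 is estimated at 4 nM, with a range from 1.2 nM to 15 nM.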

Compound 4, half-maximal inhibitory concentration: 0.89 nM
Compound 4: the middle estimate sits 4.5-fold (0.65 log units) above what was measured; the measured number lies below the stated range.
By their numbers in this assay, from the lowest: compound 4; then compound 2; then compound 1; then compound 3.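

In this assay the exchange of phenethyl for phenylsulfanyl gives a 2.7-fold lower number from compound 2 to compound 4 (0.43 log units; beyond the scatter) and so shows that this aromatic carbon, meta to a large group, tolerates a change of the linker to the outer ring without loss and with a modest gain. Sulfur therefore carries no single penalty in this series: the core exchange of ethylsulfanyl for ethoxy gave a 43-fold higher number from compound 1 to compound 3 (1.64 log units; beyond the scatter) in the opposite direction, though that step differs from this one in both place and group. No measurement at hand accounts for the gain at this position.

The compounds shown leave open whether the gain is specific to phenylsulfanyl or would extend to phenoxy or benzyl on the same carbon. They also leave open how an amine on the outer ring would fare.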